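The compounds below may be only part of what the source reports. "The series", "measured", "known", "first", "only" and "open" are said of these compounds alone.

In a functional assay on HL-60 cells (Homo sapiens) for cytotoxicity, read by WST assay, with a stated time of 48 h (on this read-out lower numbers stand for stronger inhibition and higher numbers for weaker inhibition), compound 1 `COc1cc(C(c2ccc(O)c(OC)c2)[C@H](C)[C@H](C)CO)ccc1O` reaches only a limit, > 100000 nM. Among the actual numbers, compound 2 `COC[C@H](C)[C@@H](C)C(c1ccc(O)c(OC)c1)c1ccc(O)c(OC)c1` stands higher at 68000 nM, and compound 3 `CCCCCCCC[C@H](C(C)C)C(c1ccc(O)c(OC)c1)c1ccc(O)c(OC)c1` gives a lower 3700 nM, a gap beyond the scatter. Compound 4 `COc1cc(C(c2ccc(O)c(OC)c2)[C@@H](C)[C@H](C)CF)ccc1O` differs from compound 2 by the change (2-(fluoromethyl)-1-methylpropyl in place of 2-(methoxymethyl)-1-methylpropyl on a saturated chain carbon bound to two aromatic carbons). Among the measured compounds shown here, the one measured step that bears on this change is an at least 1.4-fold lower number from compound 1 to compound 2 (0.16 log units; that floor lies within the scatter), which alters the same side chain, and its floor lies within the scatter. That step gives no sign of a large effect, so no shift beyond the scatter is expected, and the estimated step is a 1.1-fold lower number from compound 2 to compound 4 (0.05 log units; within the scatter). Compound 4 is expected at 60000 nM, with an estimated range of 25000 nM to 140000 nM.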

Compound 4, half-maximal inhibitory concentration: 32000 nM
Compound 4: middle estimate off by 1.9-fold (0.27 log units), on the high side; low and high end bracket the measured number.
By their numbers in this assay, from the lowest: compound 3; then compound 4; then compound 2. At a limit, above all of these: compound 1.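

In this assay, the side chain on the saturated chain carbon bound to two aromatic carbons proves responsive to a small change: 2-(fluoromethyl)-1-methylpropyl in place of 2-(methoxymethyl)-1-methylpropyl gives a 2.1-fold lower number from compound 2 to compound 4 (0.33 log units; beyond the scatter). Against the hydroxymethyl side chain, the same group gives an at least 3.1-fold lower number from compound 1 to compound 4 (0.49 log units; beyond the scatter). Compound 1 stands only at a limit, so that second step is a floor: the limit of > 100000 nM in this assay, at which 1 of the 4 values shown sits.

The compounds shown leave open whether the fluorine itself or the loss of the methoxy oxygen carries the step. They also leave open how an aminomethyl or carboxylic acid group at this chain end would read.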